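The source may report more compounds than this note shows. Statements on the series, on what has been measured and on what is new or still open speak of the compounds shown alone.

Three hydrazones built on one shared core have been measured in a physicochemical assay for lipophilicity, measured as octanol-water partition; on this read-out higher numbers stand for higher lipophilicity and lower numbers for lower lipophilicity. Compound 1 `O=C(COc1cccc2ccccc12)N/N=C/c1ccc(O)cc1` gives 3.73 in this assay, compound 2 `O=C(COc1cccc2ccccc12)N/N=C/C=C/c1ccccc1` gives 4.43, and compound 3 `O=C(COc1cccc2ccccc12)N/N=C/c1ccc(Br)cc1` gives 4.81, the highest of the three numbers, with compound 2 nearest and compound 1 furthest from it. The steps between the measured compounds are a number 0.70 log units higher from compound 1 to compound 2 (beyond the scatter), a number 0.38 log units higher from compound 2 to compound 3 (beyond the scatter) and a number 1.08 log units higher from compound 1 to compound 3 (beyond the scatter).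

Compound 4 `O=C(COc1cccc2ccccc12)N/N=C/c1ccccc1O` has not yet been measured. Against compound 3 the change is 2-hydroxyphenyl in place of 4-bromophenyl on a carbon with a double bond to nitrogen. The measured step that bears on it is the exchange of bromo and hydroxy on an aromatic carbon, a number 1.08 log units higher from compound 1 to compound 3 (beyond the scatter), a large step, although in compound 1 the group stood as 4-hydroxyphenyl whereas in compound 4 it enters as 2-hydroxyphenyl. Running that exchange the other way, a drop of comparable size is expected in this assay, so the expected step is a number 0.96 log units lower from compound 3 to compound 4 (beyond the scatter). Compound 4 is therefore estimated at 3.85, with a range from 3.35 to 4.35.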

Compound 4, partition coefficient: 3.73
Beside the measured number, compound 4's estimate is 0.12 log units above it, within the range that was stated.
By their numbers in this assay, from the lowest: compounds 1 and 4 (each within the scatter of the next); then compound 2; then compound 3.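

In this assay the two hydroxyphenyl groups on the carbon with a double bond to nitrogen are not told apart, with no change at the digits printed from compound 1 to compound 4 (within the scatter), so the site of the hydroxy on this phenyl ring carries no visible weight for this pair. Within the data shown here, the 2-hydroxyphenyl group also stands well under both other groups, with a number 1.08 log units lower from compound 3 to compound 4 (beyond the scatter) and a number 0.70 log units lower from compound 2 to compound 4 (beyond the scatter), and so compounds 1 and 4 both sit under compound 2 and compound 3, with no compound here going against that grouping. Nothing on hand gives a reason for these numbers.

On these data alone, whether the same holds for other groups stays open: an amine or a carboxylic acid in place of the hydroxy on this phenyl ring could fall with compounds 1 and 4 or apart from them. Equally open, as far as these compounds go, is whether a methoxy group in place of the hydroxy would keep the two sites alike.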